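Fluorine Added to the Sulfonyl Ring: What to Expect

The source may report more compounds than this note shows. Statements on the series, on what has been measured and on what is new or still open speak of the compounds shown alone.

Measured compounds:
compound 1 `O=S(=O)(c1ccccc1)c1nc2ccccc2nc1Nc1ccccc1` — 1630 nM
compound 2 `COc1cc(Nc2nc3ccccc3nc2S(=O)(=O)c2ccccc2)cc(OC)c1` — 950 nM
compound 3 `O=S(=O)(c1ccccc1)c1nc2ccccc2nc1Nc1ccc(Cl)cc1` — 2000 nM

In a functional assay on HCT-116 cells (Homo sapiens) for cytotoxicity, read by MTT assay, with a stated time of 72 h (on this read-out higher numbers stand for weaker inhibition and lower numbers for stronger inhibition), compound 2 gives the lowest of the three numbers. Its distance from compound 1 is small: a 1.7-fold lower number from compound 1 to compound 2 (0.23 log units; within the scatter). Its distance from compound 3 is a little larger: a 2.1-fold higher number from compound 2 to compound 3 (0.32 log units; beyond the scatter), a modest step.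

Compound 4 `COc1cc(Nc2nc3ccccc3nc2S(=O)(=O)c2ccc(F)cc2)cc(OC)c1` differs from compound 2 in one place: fluoro in place of hydrogen on an aromatic carbon. For the measured compounds named here, no measured pair changes anything on the phenylsulfonyl group itself, so no step speaks to this exact spot. The nearest comparison is compound 1 to compound 3, where a halogen replaces hydrogen on an aromatic carbon, but on the 4-chlorophenyl bound to nitrogen: a 1.2-fold higher number from compound 1 to compound 3 (0.09 log units; within the scatter), within the scatter. On that evidence, a fluoro on a different ring is expected to give no step beyond the scatter in this assay, in either direction.

Compound 4 is therefore expected to give about 950 nM, with a likely range from 400 nM to 2200 nM. The expected step is no change at the digits printed from compound 2 to compound 4 (within the scatter).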

Compound 4, half-maximal inhibitory concentration: 3930 nM
Compound 4: middle estimate off by 4.1-fold (0.62 log units), on the low side, and the stated range ends below it.
By their numbers in this assay, from the lowest: compounds 2, 1, 3 and 4 (each within the scatter of the next, the first and the last beyond it).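

The phenylsulfonyl group is not a silent spot in this assay: a single fluoro, placed para to a large group, gives a 4.1-fold higher number from compound 2 to compound 4 (0.62 log units; beyond the scatter), so this small change on that ring is enough to leave the scatter. That sets it apart from the only other halogen step shown, where chloro on the ring bound to nitrogen gives a 1.2-fold higher number from compound 1 to compound 3 (0.09 log units; within the scatter) and stays within the scatter. Nothing in the data shown explains why the fluoro has this effect.

On these data alone, whether the step belongs to fluoro itself or would follow any group on this carbon stays open, and an amine or a carboxylic acid in the same place would help to tell these apart. Also open, as far as these compounds go, is whether the same fluoro would give a similar step in compound 1 or compound 3, which carry other groups on the nitrogen.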